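Moving a Methyl on the Aryl Amide of Compound 2

A few compounds are considered here, and "the series" means these few. Any claim that something is new, unique, unknown or untested is made for them only; others in the source may bear on it.

Compound 2 `CCN1CCc2c(c(C(C)(C)C)nn2C(=O)Nc2c(C)cccc2C)C1` — 15.7%
Compound 1 `CCN1CCc2c(c(C)nn2C(=O)Nc2c(C)cccc2C)C1` — 12.2%

In a functional assay on the whole organism (strain Swiss albino) for inhibition, with Mus musculus as the target, in the formalin test, with stated times of 30 min and 5 min, at a dose of 100 mg/kg (on this read-out higher numbers stand for more inhibition at the one dose given (going by the name of the read-out) and lower numbers for less inhibition), compound 2 gives 15.7%, the higher of the two numbers, while compound 1 gives 12.2%; the step of a number 3.5 percentage points higher from compound 1 to compound 2 (within the scatter) lies within the scatter. Compound 3 `CCN1CCc2c(c(C(C)(C)C)nn2C(=O)Nc2ccc(C)cc2C)C1` differs from compound 2 by 2,4-dimethylphenyl in place of 2,6-dimethylphenyl on an amide-type nitrogen. Among the measured compounds shown here, no measured step touches this change; the only step seen, from tert-butyl in place of methyl, stayed within the scatter. For compound 3 no step beyond the scatter is therefore expected in this assay, a number 0.7 percentage points lower from compound 2 to compound 3 (within the scatter), and its value is estimated at 15%, within 4% to 28%.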

Compound 3, a percentage reported as inhibition, in the whole organism at one dose (the size of the read-out at that dose, not a potency): 15.7%
Compound 3: middle estimate off by 0.7 percentage points, on the low side; the range from low to high includes it.
By their numbers in this assay, from the lowest: compounds 1, 2 and 3 (each within the scatter of the next).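

In this assay, 2,4-dimethylphenyl in place of 2,6-dimethylphenyl on the amide-type nitrogen gives no change at the digits printed from compound 2 to compound 3 (within the scatter). Among the compounds shown here, this is the first look at the aryl group, as the earlier step changed only methyl to tert-butyl on an aromatic carbon, and moving one methyl here leaves the read-out within the scatter. Nothing available explains this result.

Both changes shown stayed within the scatter, so it remains open whether this read-out responds to any change at the aryl group. A carboxylic acid or an amine on that ring, or an unsubstituted phenyl, could test this.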